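Notes on a fused-core series: phenyl for acetamido

The compounds below may be only part of what the source reports. "The series", "measured", "known", "first", "only" and "open" are said of these compounds alone.

Measured compounds:
compound 1 `NC(=O)c1ccc(-c2cn3c(-c4ccc(O)cc4)cnc3cn2)cc1`, 310 nM
compound 2 `CC(=O)Nc1cn2c(-c3ccc(O)cc3)cnc2cn1`, 789 nM

In an assay for inhibition of MAP kinase-interacting serine/threonine-protein kinase 1 (Homo sapiens), with stated times of 10 min and 60 min (a lower number here means a stronger inhibitor, a higher number a weaker inhibitor), compound 1 gives 310 nM and compound 2 gives 789 nM, the higher of the two numbers; the gap between them lies beyond the usual scatter. Compound 3 `Oc1ccc(-c2cnc3cnc(-c4ccccc4)cn23)cc1` is not yet measured. It differs from compound 2 by phenyl in place of acetamido on an aromatic carbon. Within the data shown here, no measured pair shows this change directly; compound 1, which also carries an aromatic ring in place of the acetamido, gives the lower number, so a modest shift toward a lower number is expected, near the edge of the scatter. For compound 3 the expected step is a 1.6-fold lower number from compound 2 to compound 3 (0.20 log units; within the scatter). Compound 3 is estimated at 500 nM, with a range of 150 nM to 1600 nM.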

Compound 3, half-maximal inhibitory concentration: 528 nM
Compound 3: middle estimate off by 1.1-fold (0.02 log units), on the low side; low and high end bracket the measured number.
By their numbers in this assay, from the lowest: compounds 1, 3 and 2 (each within the scatter of the next, the first and the last beyond it).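

In this assay phenyl in place of acetamido on this aromatic carbon gives a 1.5-fold lower number from compound 2 to compound 3 (0.17 log units; within the scatter), so the acetamido, with its hydrogen-bond donor and acceptor, is not needed at this position to hold a number in this range. Hydrogen in place of carbamoyl gives a 1.7-fold higher number from compound 1 to compound 3 (0.23 log units; within the scatter), so the carbamoyl is not needed either. Compound 3 thus lies within the scatter of both compound 1 and compound 2, and the gap between those two cannot be assigned to either group. Nothing at hand accounts for these steps. Still open, from the compounds shown here alone, is how an amine, a carboxylic acid or a longer chain would read at this aromatic carbon.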